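Opening the oxolane ring on the ether side chain

This account rests on a few compounds, and the source may have more. Where it says the series, first, only, none or still open, it means among the compounds named here.

Measured so far in an ADME assay (liver) for metabolic stability, with Liver microsome (Homo sapiens) as the target, using microsomes; a higher number here means faster removal of the compound, a lower number slower removal 
Compound 1 `CC(C)(C)COc1ccc(-c2cc(=O)[nH]c(N)n2)cc1` gives 6.9 mL.min-1.g-1 
Compound 2 `Nc1nc(-c2cccc(OC(F)(F)F)c2)cc(=O)[nH]1` gives 3.2 mL.min-1.g-1 
Compound 3 `Nc1nc(-c2ccc(OCC3CCOC3)cc2)cc(=O)[nH]1` gives 21 mL.min-1.g-1 

Of these three, compound 3 stands highest, and both others lie beyond the scatter from it. Compound 4 `Nc1nc(-c2ccc(OCCCCO)cc2)cc(=O)[nH]1` differs from compound 3 on a saturated chain carbon bound to an oxygen on an aromatic ring: 3-hydroxypropyl in place of oxolan-3-yl on a saturated chain carbon bound to an oxygen on an aromatic ring. The (oxolan-3-yl)methoxy group thus becomes 4-hydroxybutoxy.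

Going by the values given here, one measured step bears on this place: a 3.0-fold higher number from compound 1 to compound 3 (0.48 log units; beyond the scatter), a modest change beyond the scatter, with oxolan-3-yl in place of tert-butyl. Among the compounds with values here, no measured compound carries 3-hydroxypropyl, so this step suggests a size but gives no firm direction. Compound 3 already sits at the top, and compound 1 at 6.9 mL.min-1.g-1 lies under it, so a modest fall is more likely than a further rise. The expected change is a 1.9-fold lower number from compound 3 to compound 4 (0.28 log units; within the scatter), no larger than the measured step. Compound 4 is estimated at 11 mL.min-1.g-1, with an expected range from 4.5 mL.min-1.g-1 to 24 mL.min-1.g-1.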

Compound 4, intrinsic clearance in microsomes: 6.8 mL.min-1.g-1
The estimate for compound 4 lay 1.6-fold (0.21 log units) above the measured number; the range from low to high includes it.
By their numbers in this assay, from the lowest: compound 2; then compounds 4 and 1 (each within the scatter of the next); then compound 3.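

In this assay, opening the oxolan-3-yl ring into the 3-hydroxypropyl chain gives a 3.1-fold lower number from compound 3 to compound 4 (0.49 log units; beyond the scatter), so the number at this place moves with a change that removes the ring and adds a hydrogen-bond donor, and not only with the earlier exchange of tert-butyl for oxolan-3-yl. Set against tert-butyl, the same chain gives a 1.0-fold lower number from compound 1 to compound 4 (0.01 log units; within the scatter), so these two groups cannot be told apart here, and among the three groups at this place only oxolan-3-yl stands apart from both others. Nothing at hand explains why the number moves with these changes.

The compounds shown cannot separate the loss of the ring from the arrival of the hydroxyl end of the chain. From the compounds shown here alone, it also stays open whether a longer chain, or an amine or a carboxylic acid at the end of the chain, would lie nearer compound 3 or compound 4.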